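This account rests on a few compounds, and the source may have more. Where it says the series, first, only, none or still open, it means among the compounds named here.

Working notes on the series, read in an ADME assay on HEK-293T cells (Homo sapiens) for cytotoxicity, read by MTT assay, with a stated time of 24 h; on this read-out lower numbers stand for higher toxicity in this test and higher numbers for lower toxicity in this test. Compound 1 (`FC(F)(F)c1ccc(-c2nn(-c3ccccc3)cc2-c2nc3ccccc3[nH]2)cc1`) gives 167000 nM, compound 2 (`Cc1ccc(-c2nn(-c3ccccc3)cc2-c2nc3ccccc3n2S(=O)(=O)c2ccc(C)cc2)cc1`) gives 79300 nM, and compound 3 (`Cc1ccc(-c2nn(-c3ccccc3)cc2-c2nc3ccccc3n2S(=O)(=O)c2ccc(Br)cc2)cc1`) gives 159000 nM. Within the data shown here, compound 3 therefore stands within the scatter of both compound 1 and compound 2, so the numbers so far offer no clear separation around it.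

The next compound is compound 4 (`O=S(=O)(c1ccc(Br)cc1)n1c(-c2cn(-c3ccccc3)nc2-c2ccc(F)cc2)nc2ccccc21`), which differs from compound 3 at a single place: fluoro in place of methyl on an aromatic carbon. In words, this is 4-methylphenyl to 4-fluorophenyl. Among the measured compounds shown here, the one measured step that bears on this change is a 2.0-fold higher number from compound 2 to compound 3 (0.30 log units; within the scatter). That step also replaces methyl on an aromatic carbon, but with bromo and on another ring, so it is only a loose guide. For the measured compounds named here, no measured compound carries fluoro in this place. No shift beyond the scatter is expected in this assay, and no direction is favoured. The expected step is a 1.1-fold lower number from compound 3 to compound 4 (0.06 log units; within the scatter). Compound 4 is estimated at 140000 nM, with an expected range of 70000 nM to 280000 nM.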

Compound 4, half-maximal cytotoxic concentration: 239000 nM
Estimate against measurement, compound 4: 1.7-fold (0.23 log units) below, within the range that was stated.
By their numbers in this assay, from the lowest: compounds 2, 3, 1 and 4 (each within the scatter of the next, the first and the last beyond it).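

In this assay, among these compounds, the first measured change at this place, on an aromatic carbon para to a large group, is 4-methylphenyl to 4-fluorophenyl, and it gives a 1.5-fold higher number from compound 3 to compound 4 (0.18 log units; within the scatter). Methyl has now been replaced on two different rings, the other step being a 2.0-fold higher number from compound 2 to compound 3 (0.30 log units; within the scatter), and neither replacement moves the number beyond the scatter, so methyl is not shown to matter to this read-out at either place. No measurement of any property of these compounds bears on this result.

Going by these compounds, whether a larger or charged group at this place, such as an amine, a carboxylic acid or a longer alkyl chain, would shift the number beyond the scatter remains open. Also open, on these data alone, is whether fluoro in place of methyl reads the same when the other ring carries methyl rather than bromo.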